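The source may report more compounds than this note shows. Statements on the series, on what has been measured and on what is new or still open speak of the compounds shown alone.

Measured so far in a functional assay on L1210 cells (Mus musculus) for antiproliferative activity, with a stated time of 72 h; on this read-out higher numbers stand for an effect only at larger amounts of compound and lower numbers for an effect already at smaller amounts:

compound 1 `Cc1cn([C@@H]2O[C@H](CO)[C@@H](CN=[N+]=[N-])[C@@H]2O)c(=O)[nH]c1=O`: 10 uM
compound 2 `Cc1cn([C@H]2C[C@H](CF)[C@@H](CO)O2)c(=O)[nH]c1=O`: > 100 uM
compound 3 `Cc1cn([C@@H]2O[C@H](CO)[C@@H](CN)[C@H]2O)c(=O)[nH]c1=O`: > 100 uM

Compound 1 is the only one of these with a true number, 10 uM. Compound 2 shows > 100 uM, which is a limit of the assay and not a number. Compound 3 shows > 100 uM, which is likewise a limit.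

The next compound, compound 4 `Cc1cn([C@@H]2O[C@H](CO)[C@@H](CO)[C@@H]2O)c(=O)[nH]c1=O`, keeps the core of compound 1 and carries one change: hydroxy in place of azido on a saturated chain carbon bound to a saturated ring carbon. Hydroxy stands in place of azido on a saturated chain carbon bound to a saturated ring carbon. Among the measured compounds shown here, no measured pair shows this change, so its size in this assay has to be estimated. A higher number is expected, meaning weaker activity. For the measured compounds named here, the ground for this is thin: compound 1, at 10 uM, is the only compound here with azido and the only one giving a number. The estimated step of a 10-fold higher number from compound 1 to compound 4 (1.00 log units; beyond the scatter) is a clear move towards larger amounts. For compound 4 the expected value is 100 uM, with an estimated range of 30 uM to 300 uM.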

Compound 4, concentration for half-maximal effect: > 100 uM
Compound 4 ended at the assay's limit; the forecaster's own chance of this, stated with the estimate: 70%; the middle value lies on the limit itself.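

In this assay, hydroxy in place of azido on a saturated chain carbon bound to a saturated ring carbon gives an at least 10-fold higher number from compound 1 to compound 4 (1.00 log units; beyond the scatter). Among the compounds shown here, this is the first pair here that differs in one place only, so it shows that the group at this position matters and that the measurable activity of compound 1 does not survive this change. Only one end of the step is fixed, because the readings stop at the same limit: the limit of > 100 uM in this assay, at which 3 of the 4 values shown sit.

Compound 2 and compound 3 each differ from compound 1 in more than one place, so they cannot show which feature of azidomethyl counts. From the compounds shown here alone, it also remains open whether a nitrile, a carboxylic acid or a longer chain ending in azido at this place would give a true number in this assay.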